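Trifluoromethyl in place of chloro on an aromatic carbon

The compounds below may be only part of what the source reports. "The series", "measured", "known", "first", "only" and "open" are said of these compounds alone.

Three compounds share one core and differ only in the aromatic group on an amine nitrogen in a ring. In a functional assay on HL-60 cells (Homo sapiens) for inhibition, read by MTT assay, with a stated time of 72 h (a lower number here means a stronger inhibitor, a higher number a weaker inhibitor), compound 1 `Cc1nc(-c2ccccc2)c(C(=O)N2CCN(c3cccc(Cl)c3)CC2)o1`, with 3-chlorophenyl, gives 39.2 nM. Compound 2 `Cc1ccc(N2CCN(C(=O)c3oc(C)nc3-c3ccccc3)CC2)c(C)c1`, with 2,4-dimethylphenyl, gives 101 nM, and compound 3 `Cc1nc(-c2ccccc2)c(C(=O)N2CCN(c3ccccc3Cl)CC2)o1`, with 2-chlorophenyl, gives 124 nM. Compound 3 has the highest number of the three, but the data show a 1.2-fold higher number from compound 2 to compound 3 (0.09 log units; within the scatter), so it cannot be separated from compound 2. Its gap to the best number is real, at a 3.2-fold higher number from compound 1 to compound 3 (0.50 log units; beyond the scatter).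

Compound 4 `Cc1nc(-c2ccccc2)c(C(=O)N2CCN(c3ccccc3C(F)(F)F)CC2)o1` follows from compound 3 by one change: trifluoromethyl in place of chloro on an aromatic carbon. In words, trifluoromethyl replaces chloro on an aromatic carbon, ortho to a large group. Going by the values given here, no measured pair makes this exact swap, so the guide is indirect. Among the compounds with values here, the closest precedent is the exchange of 2,4-dimethylphenyl for 2-chlorophenyl, which gave a 1.2-fold higher number from compound 2 to compound 3 (0.09 log units; within the scatter). The larger steps, a 2.6-fold higher number from compound 1 to compound 2 (0.41 log units; beyond the scatter) and a 3.2-fold higher number from compound 1 to compound 3 (0.50 log units; beyond the scatter), are still modest and both start from 3-chlorophenyl, a group compound 4 lacks. No step beyond the scatter is therefore expected in this assay. The estimate is a 1.0-fold lower number from compound 3 to compound 4 (0.01 log units; within the scatter). Compound 4 is expected at about 120 nM, with an estimated range from 50 nM to 290 nM.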

Compound 4, half-maximal inhibitory concentration: 120 nM
Beside the measured number, compound 4's estimate shows no gap at the digits printed; low and high end bracket the measured number.
By their numbers in this assay, from the lowest: compound 1; then compounds 2, 4 and 3 (each within the scatter of the next).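

In this assay, the result shows that this position, on an aromatic carbon ortho to a large group, accepts trifluoromethyl in place of chloro with no change that can be told from the scatter, even though trifluoromethyl carries more heavy atoms: the data give a 1.0-fold lower number from compound 3 to compound 4 (0.01 log units; within the scatter). The 2-(trifluoromethyl)phenyl group also cannot be separated from 2,4-dimethylphenyl, with a 1.2-fold higher number from compound 2 to compound 4 (0.07 log units; within the scatter), while 3-chlorophenyl stays apart, with a 3.1-fold higher number from compound 1 to compound 4 (0.49 log units; beyond the scatter), a modest step that leaves compound 1 with the lowest number of the four. No measurement shown here offers an explanation for this result.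

The compounds shown leave open whether a fluoro, methoxy or nitrile group in the same place would also fit this flat picture, and whether an amine or a carboxylic acid there would break it. They also leave open whether trifluoromethyl in the place that holds chloro in compound 1 would keep the lower number of that compound.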